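Dropping the Hydroxymethyl: What Cytotoxicity to Expect

This account rests on a few compounds, and the source may have more. Where it says the series, first, only, none or still open, it means among the compounds named here.

Measured compounds:
Compound 1, `COc1ccccc1-c1nccc2[nH]c(C(C)(C)O)cc12`: "not determined" (no result reported)
Compound 2, `CC(C)(O)c1cc2c(-c3ccc(C(F)(F)F)cc3)nccc2[nH]1`: 72300 nM
Compound 3, `CC(C)(O)c1cc2c(-c3ccccc3CO)nccc2[nH]1`: "not determined" (no result reported)

The three measured compounds share one core and differ only in the substituent on the aryl ring attached to it. Going by the values given here, in an ADME assay on U2OS cells (Homo sapiens) for cytotoxicity (a higher number here means that more compound is tolerated, a lower number that less compound is tolerated), compound 2 gives 72300 nM, and that is the only number the series offers. Compound 3 stands without a single number in this assay, its entry reading "not determined" (no result reported), and compound 1 stands beside it in the same position, its entry likewise reading "not determined" (no result reported). Among the compounds with values here, no step between two measured compounds can therefore be computed.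

The compound still to be tested is compound 4, `CC(C)(O)c1cc2c(-c3ccccc3)nccc2[nH]1`. It differs from compound 3 in one place: hydrogen in place of hydroxymethyl on an aromatic carbon.

Within the data shown here, with no measured step to lean on, the size of the change from compound 3 to compound 4 in this assay cannot be judged from the data; a step within the usual scatter, in either direction, is the plainest expectation. Among the measured compounds shown here, the only anchor is compound 2, whose value of 72300 nM is far from the low end of what the assay can resolve.

For compound 4 in this assay the estimated value is 60000 nM, with an expected range from 20000 nM to 150000 nM.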

Compound 4, half-maximal cytotoxic concentration: 22200 nM
Compound 4: middle estimate off by 2.7-fold (0.43 log units), on the high side; low and high end bracket the measured number.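

Compound 4 gives the series its first readable comparison in this assay and shows that this aryl ring's substitution can matter: the step of a 3.3-fold lower number from compound 2 to compound 4 (0.51 log units; beyond the scatter) lies beyond the usual scatter. With hydrogen in place of trifluoromethyl on an aromatic carbon, the number moves to the less tolerated side, so the substituent on this ring is not a silent feature of the series in this pair. Steps to compound 1 and compound 3 cannot be read, as their entries hold no single number, which leaves the effect of losing hydroxymethyl without a size, and nothing available accounts for the shift seen with trifluoromethyl.

The compounds shown leave open how far the number would move with an amine, a carboxylic acid or a longer chain on this aromatic carbon, ortho to a large group. They also leave open whether such a group would raise or lower the number relative to the unsubstituted ring of compound 4, and whether any trend would hold across more than this one readable pair.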